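Methyl to Ethyl and Tolerance in a Cell Toxicity Assay

This account rests on a few compounds, and the source may have more. Where it says the series, first, only, none or still open, it means among the compounds named here.

Compound 1 `Cc1ccc2[nH]c(=O)c(CN(Cc3ccc(F)cc3)Cc3ccc(-c4ccccc4)cc3)cc2c1` and compound 2 `CCc1ccc2[nH]c(=O)c(CN(Cc3ccc(F)cc3)Cc3ccc(-c4ccccc4)cc3)cc2c1` were tested in a toxicity assay on MDCK cells (Canis lupus familiaris) for cytotoxicity, read by crystal violet staining, with a stated time of 48 h; a higher number here means that more compound is tolerated, a lower number that less compound is tolerated. For compound 1 the result is a limit of the assay, > 5000 nM. For compound 2 the result is likewise a limit, > 5000 nM. The change between them is methyl in place of hydrogen on a saturated chain carbon bound to an aromatic carbon, and the step that the two limits leave unreadable from compound 1 to compound 2 cannot be sized, which rests on (the limit of > 5000 nM in this assay, at which 2 of the 3 values shown sit). For the measured compounds named here, compound 3 `COCOc1ccc(CN(Cc2ccc(C(C)(C)C)cc2)Cc2cc3cc(C)ccc3[nH]c2=O)cc1` gives 6400 nM in this assay, the only number among the three results. How the core of compound 3 differs from that of compound 1 is not broken down here. Compound 4 `CCc1ccc2[nH]c(=O)c(CN(Cc3ccc(OCOC)cc3)Cc3ccc(C(C)(C)C)cc3)cc2c1` differs from compound 3 by methyl in place of hydrogen on a saturated chain carbon bound to an aromatic carbon, the same change as before. Compound 4 is expected to show an estimated step of a 1.1-fold lower number from compound 3 to compound 4 (0.03 log units; within the scatter) in this assay, since the measured step that the two limits leave unreadable from compound 1 to compound 2 gives no readable size. Compound 4 is estimated at 6000 nM, between 2500 nM and 15000 nM.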

Compound 4, half-maximal cytotoxic concentration: > 10000 nM
Compound 4: only a limit was reported; the forecaster's own chance of this, stated with the estimate: 40%; middle value at least 1.6-fold (0.22 log units) from the limit.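

In this assay, the change of methyl to ethyl on the core of compound 3 gives an at least 1.5-fold higher number from compound 3 to compound 4 (0.19 log units; that floor lies within the scatter), a floor that does not by itself establish a real difference. For compound 4 the result is a limit of the assay, > 10000 nM. The matching step on the core of compound 1 cannot be read, so the series offers one bounded step and no true comparison of the change on two cores, because both of those results are limits: the limit of > 5000 nM in this assay, at which 2 of the 4 values shown sit.

The compounds shown leave open how a longer chain such as propyl, or an amine, on the saturated chain carbon bound to an aromatic carbon would read in this assay. They also leave open how far the tolerated concentration of the ethyl compounds extends.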